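From Compound 2 to Compound 3: Changing the Amide

The compounds below may be only part of what the source reports. "The series", "measured", "known", "first", "only" and "open" are said of these compounds alone.

Compound 1, `COc1cccc(CNC(=O)c2nn(-c3ccc(F)cc3)c(OC[C@@H](O)C[C@@H](O)CC(=O)O)c2C(C)C)c1`: 16 nM
Compound 2, `COCc1cccc(CNC(=O)c2nn(-c3ccc(F)cc3)c(OC[C@@H](O)C[C@@H](O)CC(=O)O)c2C(C)C)c1`: 31 nM

In an assay on microsomes from liver for inhibition of 3-hydroxy-3-methylglutaryl-coenzyme A reductase (Rattus norvegicus) (on this read-out higher numbers stand for weaker inhibition and lower numbers for stronger inhibition), compound 2 gives 31 nM, the highest of the two numbers measured, while compound 1 gives 16 nM. Within the data shown here, the one measured step, a 1.9-fold higher number from compound 1 to compound 2 (0.29 log units; within the scatter), lies within the scatter, so the two compounds cannot be ordered.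

Compound 3, `Cc1cccc(CN(C)C(=O)c2nn(-c3ccc(F)cc3)c(OC[C@@H](O)C[C@@H](O)CC(=O)O)c2C(C)C)c1`, has not yet been measured. It differs from compound 2 by methyl(3-methylbenzyl)amino in place of (3-(methoxymethyl)benzyl)amino on a carbonyl carbon. The change touches two things at once: the substituent on the aromatic ring and the amide nitrogen, which loses its hydrogen and gains a methyl. The measured step from compound 1 to compound 2 bears only on the first part, and it was small. For the second part there is no measured comparison at all, so the expectation rests on little.

Compound 3 is therefore expected to lie near compound 2, with a modest move toward a higher number being the more likely outcome, giving an estimated step of a 1.9-fold higher number from compound 2 to compound 3 (0.29 log units; within the scatter). The estimate for compound 3 in this assay is 60 nM, with a range from 15 nM to 300 nM.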

Compound 3, half-maximal inhibitory concentration: 37 nM
The estimate for compound 3 lay 1.6-fold (0.21 log units) above the measured number; the range from low to high includes it.
By their numbers in this assay, from the lowest: compounds 1, 2 and 3 (each within the scatter of the next, the first and the last beyond it).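

In this assay, putting methyl(3-methylbenzyl)amino in place of (3-(methoxymethyl)benzyl)amino on the carbonyl carbon gives a 1.2-fold higher number from compound 2 to compound 3 (0.08 log units; within the scatter) and so leaves the two compounds unordered, even though the amide hydrogen is gone and the oxygen of the side chain with it. Set against the (3-methoxybenzyl)amino group, the same methyl(3-methylbenzyl)amino group gives a 2.3-fold higher number from compound 1 to compound 3 (0.36 log units; beyond the scatter) and thereby provides the first step in this series to pass the scatter, though only modestly. Nothing available explains either step.

The compounds shown leave open which part of the change carries that modest step, as none of them pairs the methyl on the amide nitrogen with a methoxy or methoxymethyl group on the ring, or the amide hydrogen with a plain methyl group on the ring. Also open, on these data alone, is how this read-out would respond to an ethyl group on the amide nitrogen, or to a hydroxymethyl or aminomethyl group on the ring.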